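From 2-ethylphenyl to 2,6-dichlorophenyl on a shared core

The source may report more compounds than this note shows. Statements on the series, on what has been measured and on what is new or still open speak of the compounds shown alone.

Measured so far in a functional assay (muscle tissue) with Cavia porcellus as the target; a higher number here means that more compound is needed for the effect, a lower number that less compound is needed
- compound 1 `COC(=O)C1=C(C)N=C(C)/C(=C(\O)OC)C1c1ccc(F)cc1` gives 129 nM
- compound 2 `CCc1ccccc1C1C(C(=O)OC)=C(C)N=C(C)/C1=C(\O)OC` gives 6.46 nM

Compound 2 has the lower of these two numbers, meaning that less of it is needed for the effect. Compound 3 `COC(=O)C1=C(C)N=C(C)/C(=C(\O)OC)C1c1c(Cl)cccc1Cl` has not yet been measured. It keeps the shared core and carries 2,6-dichlorophenyl in place of 2-ethylphenyl on a saturated ring carbon. Among the compounds with values here, one measured step bears on this place: a 20-fold lower number from compound 1 to compound 2 (1.30 log units; beyond the scatter). That large step shows that swapping the group here can move the number in this assay well beyond the scatter. The entering and leaving groups both carry a substituent numbered 2, unlike the 4-fluorophenyl of compound 1. Compound 3 is therefore expected to lie nearer compound 2, with a moderate rise as the expected direction. The expected change is a 3.1-fold higher number from compound 2 to compound 3 (0.49 log units; beyond the scatter). For compound 3 the estimated value is 20 nM, with an expected range from 5 nM to 80 nM.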

Compound 3, half-maximal effective concentration: 1.91 nM
The estimate for compound 3 lay 10-fold (1.02 log units) above the measured number, and the stated range ends above it.
By their numbers in this assay, from the lowest: compound 3; then compound 2; then compound 1.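

Swapping 2-ethylphenyl for 2,6-dichlorophenyl gives a 3.4-fold lower number from compound 2 to compound 3 (0.53 log units; beyond the scatter) in this assay and shows that this position can still lower the number after the gain seen with compound 2. Measured from the 4-fluorophenyl group, the change amounts to a 68-fold lower number from compound 1 to compound 3 (1.83 log units; beyond the scatter) and is the largest step seen here, so both groups with a substituent numbered 2 lie well below compound 1, and neither compound shown goes against this. No supporting data bear on why 2,6-dichlorophenyl gives the lowest number.

From the compounds shown here alone, whether 2-chlorophenyl, with its single chlorine, would keep the number this low remains open, as does the effect of an aminophenyl or carboxyphenyl group here. Also open, going by these compounds, is how a longer ester chain in place of the methoxycarbonyl group would act alongside 2,6-dichlorophenyl.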